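Ring oxygen removed from the aryl ether pair

The compounds below may be only part of what the source reports. "The series", "measured", "known", "first", "only" and "open" are said of these compounds alone.

Of the compounds shown here, three have been measured in a physicochemical assay for lipophilicity, read by LC-MS, in phosphate buffer, measured as octanol-water partition, with a stated time of 30 min, at pH 7.4, tested at 200 mM; a higher number here means a more lipophilic compound, a lower number a more polar compound. Compound 1 `Cn1c(COc2cccc(C(=O)O)c2)nc2ccc(Oc3ccc4c(c3)CCC4)nc21` gives 2.5, compound 2 `Cn1c(COc2cccc(C(=O)O)c2)nc2ccc(Oc3ccc4c(c3)OCC4)nc21` gives 1.4, and compound 3 `Cn1c(COc2cccc(C(=O)O)c2)nc2cnc(Oc3ccc4c(c3)OCC4)cc21` gives 0.6. Compound 1 and compound 2 share one core and differ only in the group on the ether oxygen: a group of 9 heavy atoms (9 carbon; one five-membered non-aromatic ring of carbon only, one six-membered aromatic ring of carbon only) in place of a group of 9 heavy atoms (8 carbon, 1 oxygen; one five-membered non-aromatic ring with 1 hetero atom, one six-membered aromatic ring of carbon only), on an oxygen on an aromatic ring. Across that change the reading is a number 1.10 log units higher from compound 2 to compound 1 (beyond the scatter). Compound 2 and compound 3 are built from the same atoms joined differently; the difference between the two cores is not broken down here, and in this assay compound 3 stands lower than compound 2.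

Compound 4 `Cn1c(COc2cccc(C(=O)O)c2)nc2cnc(Oc3ccc4c(c3)CCC4)cc21` has not yet been measured. It differs from compound 3 by a group of 9 heavy atoms (9 carbon; one five-membered non-aromatic ring of carbon only, one six-membered aromatic ring of carbon only) in place of a group of 9 heavy atoms (8 carbon, 1 oxygen; one five-membered non-aromatic ring with 1 hetero atom, one six-membered aromatic ring of carbon only), on an oxygen on an aromatic ring, the same change, at the same place, as that from compound 2 to compound 1. Because the earlier step of a number 1.10 log units higher from compound 2 to compound 1 (beyond the scatter) was large and beyond the scatter, a rise of similar size is expected for compound 4, namely a number 1.10 log units higher from compound 3 to compound 4 (beyond the scatter). In this assay compound 4 is therefore estimated at 1.7, expected to lie between 1.3 and 2.1.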

Compound 4, distribution coefficient: 1.6
Beside the measured number, compound 4's estimate is 0.10 log units above it; measured number inside the range.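

In this assay, the 2,3-dihydro-1H-inden-5-yl group entering on the oxygen on an aromatic ring gives a number 1.00 log units higher from compound 3 to compound 4 (beyond the scatter) on one core, while the same change on the other core gave a number 1.10 log units higher from compound 2 to compound 1 (beyond the scatter). The change therefore carries over between these two cores in the same direction, and both steps lie beyond the scatter. Going by these compounds alone, this rests on only two matched pairs, however, so it does not show that the step would hold on any further core, and nothing measured here bears on what lies behind it.

The compounds shown leave open whether a different group on that oxygen, such as a longer chain or a ring bearing an amine, would also carry over from one core to the other. They also leave open whether the same step would appear if the carboxylic acid shared by all four compounds were replaced by an amide.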